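A Longer Chain on an Inactive Nitrone

This account rests on a few compounds, and the source may have more. Where it says the series, first, only, none or still open, it means among the compounds named here.

Compound 1 `CCCCCCCCCCn1cc(/C=[N+](\[O-])c2ccccc2)nn1` and compound 2 `CCCCCCCCn1cc(/C=[N+](\[O-])Cc2ccccc2)nn1` share one core and differ in the length of the saturated chain on one side and in whether the nitrone nitrogen carries a phenyl or a benzyl group on the other. In a functional assay on PC-3 cells (Homo sapiens) for inhibition, read by MTT assay, with a stated time of 24 h (a higher number here means a weaker inhibitor, a lower number a stronger inhibitor), compound 1 gives > 100000 nM, which is a limit of the assay rather than a number. In this assay compound 2 gives > 100000 nM, again a limit of the assay and not a measured number. For the measured compounds named here, both values thus sit at the limit of > 100000 nM in this assay, at which 2 of the 2 values shown sit, so nothing separates compound 2 from the only other compound measured.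

Compound 3 `CCCCCCCCCCn1cc(/C=[N+](\[O-])Cc2ccccc2)nn1` has not yet been measured. It differs from compound 2 by ethyl in place of hydrogen on a saturated chain carbon, eight bonds along the chain from an aromatic nitrogen. No measured pair of compounds is separated by such a change, so the size of this step cannot be read from the data shown. The expected step is a step that the limit leaves unreadable from compound 2 to compound 3, that is, nothing beyond the usual scatter in either direction. Compound 3 is accordingly estimated at 150000 nM, within a range from 50000 nM to 500000 nM, and this assay is expected to report only a limit once more.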

Compound 3, half-maximal inhibitory concentration: > 100000 nM
Compound 3 was reported as a limit; the forecaster's own chance of this, stated with the estimate: 85%; the middle value lies beyond the limit too.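

In this assay compound 3 gives > 100000 nM, again a limit of the assay and not a number. No new step can therefore be read from compound 3 to compound 1 or compound 2: the limit of > 100000 nM in this assay, at which 3 of the 3 values shown sit.

The compounds shown leave open whether the chain or the phenyl or benzyl group changes inhibition at all.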